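Swapping the Aryl Group on a Sulfonamide

A few compounds are considered here, and "the series" means these few. Any claim that something is new, unique, unknown or untested is made for them only; others in the source may bear on it.

Compound 1, `CN(C(=O)CCc1ccccc1)c1ccc2[nH]c(-c3n[nH]c4ccccc34)cc2n1`, gives 4730 nM in a functional assay on HL-60 cells (Homo sapiens) for antiproliferative activity, read by MTT assay, with a stated time of 72 h; a lower number here means a stronger inhibitor, a higher number a weaker inhibitor.
Compound 2, `CN(C(=O)c1ccc(F)cc1)c1ccc2[nH]c(-c3n[nH]c4ccccc34)cc2n1`, gives 1210 nM in this assay.
Compound 3, `CN(c1ccc2[nH]c(-c3n[nH]c4ccccc34)cc2n1)S(=O)(=O)c1ccc(Br)cc1`, gives 6240 nM in this assay.

Compound 3 has the highest number of the three. Its nearest neighbour is compound 1, separated by a 1.3-fold higher number from compound 1 to compound 3 (0.12 log units; within the scatter), a gap within the scatter; its furthest is compound 2, separated by a 5.2-fold higher number from compound 2 to compound 3 (0.71 log units; beyond the scatter), a gap beyond it. Within the data shown here, the one step that touches only the group at the end of the chain, a 3.9-fold lower number from compound 1 to compound 2 (0.59 log units; beyond the scatter), was modest.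

Compound 4, `COc1ccc(S(=O)(=O)N(C)c2ccc3[nH]c(-c4n[nH]c5ccccc45)cc3n2)c(OC)c1`, differs from compound 3 by 2,4-dimethoxyphenyl in place of 4-bromophenyl on a sulfonyl sulfur. Among the measured compounds shown here, no measured step changes the substituent on an aryl group attached to a sulfonyl sulfur; the two steps that reach compound 3 each alter the sulfonyl and the aryl group at once, and the single step that alters only the pendant group, from compound 1 to compound 2, is modest. The data therefore give no ground for expecting a step beyond the scatter, though a shift of modest size in either direction cannot be excluded.

Compound 4 is expected to show a 1.2-fold lower number from compound 3 to compound 4 (0.10 log units; within the scatter), and its estimated value in this assay is 5000 nM, with a range from 1800 nM to 14000 nM.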

Compound 4, half-maximal inhibitory concentration: 5180 nM
Compound 4: the middle estimate sits 1.0-fold (0.02 log units) below what was measured; measured number inside the range.
By their numbers in this assay, from the lowest: compound 2; then compounds 1, 4 and 3 (each within the scatter of the next).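

Among these compounds, this is the first measured step that changes only the aryl group on the sulfonyl sulfur, and in this assay it reads a 1.2-fold lower number from compound 3 to compound 4 (0.08 log units; within the scatter) and leaves 2,4-dimethoxyphenyl and 4-bromophenyl indistinguishable at this position. The exchange removes the bromine and brings in a larger group with hydrogen-bond acceptors that 4-bromophenyl lacks, yet the numbers of compound 3 and compound 4 cannot be separated, so this difference in the aryl group has no readable effect in this pair. No measurement is available here that would give a reason for this result.

The compounds shown leave open whether an aryl group bearing an amine or a carboxylic acid, or a longer alkyl chain in place of the aryl group on the sulfonyl sulfur, would give a number that stands clear of those of compound 3 and compound 4. They also leave open what the sulfonyl contributes apart from the aryl group, as no pair shown carries the same aryl group on both a carbonyl and a sulfonyl sulfur.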